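The source may report more compounds than this note shows. Statements on the series, on what has been measured and on what is new or still open speak of the compounds shown alone.

Compound 1 `CC#CC(CC(=O)O)c1ccc(OCc2ccc3nc(-c4ccc(F)cc4F)cn3c2)cc1` gives 825 nM in an assay on isolated protein for agonist activity at Free fatty acid receptor 1 (Homo sapiens); on this read-out lower numbers stand for an effect already at smaller amounts and higher numbers for an effect only at larger amounts of compound. Compound 2 `CC#CC(CC(=O)O)c1ccc(OCc2ccn3cc(-c4ccc(C(F)(F)F)cc4)nc3c2)cc1` gives 674 nM. Compound 3 `CC#CC(CC(=O)O)c1ccc(OCc2ccn3cc(-c4cc(F)ccc4F)nc3c2)cc1` gives 639 nM.

Compound 1 stands highest of the three numbers, but its gaps to compound 2 and to compound 3 are both within the scatter, so no order among them can be read. The step to compound 4 `CC#CC(CC(=O)O)c1ccc(OCc2ccc3nc(-c4ccc(C)cc4)cn3c2)cc1` swaps the aryl group on the core: 4-methylphenyl in place of 2,4-difluorophenyl on an aromatic carbon. Within the data shown here, only one measured step exchanges that aryl group, a 1.1-fold lower number from compound 2 to compound 3 (0.02 log units; within the scatter), and it stayed within the scatter. On that basis no step beyond the scatter is expected in this assay for compound 4. Compound 4 is therefore estimated at 800 nM, with a range from 300 nM to 2200 nM. The expected step is a 1.0-fold lower number from compound 1 to compound 4 (0.01 log units; within the scatter).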

Compound 4, half-maximal effective concentration: 507 nM
For compound 4 the middle estimate is 1.6-fold (0.20 log units) above the measured one; the measured number falls inside the stated range.
By their numbers in this assay, from the lowest: compounds 4, 3, 2 and 1 (each within the scatter of the next).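

In this assay the exchange of fluorine-bearing aryl for 4-methylphenyl gives a 1.6-fold lower number from compound 1 to compound 4 (0.21 log units; within the scatter), so this position on the core of compound 1 also shows no change that can be read. Among these compounds, the earlier exchange sat on the core of compound 2, and compound 4 is the first here whose aryl group carries no fluorine. No measured evidence explains this result. From the compounds shown here alone, it remains open whether an amine or a carboxylic acid on this phenyl ring, or a saturated cyclohexyl ring in its place, would give a step beyond the scatter.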